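The source may report more compounds than this note shows. Statements on the series, on what has been measured and on what is new or still open speak of the compounds shown alone.

Compound 1 `COc1ccc(S(=O)(=O)Nc2ccc3oc(-c4ccc(NC(=O)c5cccc(C)c5[N+](=O)[O-])cc4)nc3c2)cc1` gives > 100000 nM
Compound 2 `COc1c(Br)cccc1C(=O)Nc1ccc(Sc2nc3ccccc3s2)cc1` gives > 100000 nM

In an ADME assay on FHC cells (Homo sapiens) for cytotoxicity, read by resazurin assay, with a stated time of 48 h (a higher number here means that more compound is tolerated, a lower number that less compound is tolerated), compound 1 gives > 100000 nM as a limit of the assay and not a number. Compound 2 gives > 100000 nM as a limit too. Within the data shown here, compound 1 therefore stands at the limit of > 100000 nM in this assay, at which 2 of the 2 values shown sit, and has no exact value so far.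

Compound 3 `COc1ccc(S(=O)(=O)Nc2ccc3oc(-c4ccc(NC(=O)C5CCN(C(C)=O)CC5)cc4)nc3c2)cc1` has not yet been measured. It carries 1-acetylpiperidin-4-yl in place of 3-methyl-2-nitrophenyl on a carbonyl carbon, and the full count reads 1-acetylpiperidin-4-yl in place of 3-methyl-2-nitrophenyl on a carbonyl carbon for this swap. Among the measured compounds shown here, no step between measured compounds is available as a guide, so the expectation rests on compound 1 at the limit of > 100000 nM in this assay, at which 2 of the 2 values shown sit, alone. The step of a number no higher from compound 1 to compound 3 (the limit leaves the size open) is expected to stay within the usual scatter, with no clear direction. The estimated value for compound 3 is 100000 nM with an expected range from 30000 nM to 200000 nM in this measurement.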

Compound 3, half-maximal cytotoxic concentration: > 100000 nM
Compound 3 ended at the assay's limit; the forecaster's own chance of this, stated with the estimate: 85%; the middle value lies on the limit itself.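

In this assay compound 1 and compound 3 both give only a limit of the assay, so no step can be read for 1-acetylpiperidin-4-yl in place of 3-methyl-2-nitrophenyl. The compounds shown leave open at what concentration any of them becomes toxic to these cells.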